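A Phenyl Group Swapped for a Halogenated Benzyl Group

The source may hold more compounds than are shown below. What is called first, only, known or untested is meant among the compounds shown, and "the series" means these compounds.

Going by the values given here, compound 2 `COc1cccc(CNCCCNc2ccnc3cc(-c4ccccc4)ccc23)c1O` gives 237 10^-6 cm/s in an ADME assay for permeability, using PAMPA, with a stated time of 30 min, at pH 7.4 (on this read-out lower numbers stand for lower permeability and higher numbers for higher permeability), the higher of the two numbers measured so far; compound 1 `COc1cccc(CNCCCNc2ccnc3cc(Cc4ccc(C#N)cc4)ccc23)c1O` gives 23 10^-6 cm/s. Compound 3 `COc1cccc(CNCCCNc2ccnc3cc(Cc4ccc(F)cc4Cl)ccc23)c1O` is not yet measured and differs from compound 2 by 2-chloro-4-fluorobenzyl in place of phenyl on an aromatic carbon. Among the compounds with values here, the one measured step, a 10-fold higher number from compound 1 to compound 2 (1.01 log units; beyond the scatter), also trades a benzyl group for phenyl at this position, though that benzyl group carried a nitrile rather than chlorine and fluorine, so it bears on the new step only loosely. A step of a 1.6-fold lower number from compound 2 to compound 3 (0.20 log units; within the scatter) is therefore expected, modest beside that measured step. Compound 3 is estimated at 150 10^-6 cm/s, within 60 10^-6 cm/s to 350 10^-6 cm/s.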

Compound 3, apparent permeability: 23 10^-6 cm/s
Compound 3: the middle estimate sits 6.5-fold (0.81 log units) above what was measured; measured number outside the range, below it.
By their numbers in this assay, from the lowest: compounds 1 and 3 (each within the scatter of the next); then compound 2.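

In this assay the change to 2-chloro-4-fluorobenzyl gives a 10-fold lower number from compound 2 to compound 3 (1.01 log units; beyond the scatter) and so is no small adjustment at this position. Comparing the two benzyl compounds, 2-chloro-4-fluorophenyl in place of 4-cyanophenyl gives no change at the digits printed from compound 1 to compound 3 (within the scatter) and so the nitrile and the two halogens cannot be told apart here, while both compounds stand well under compound 2. No measured evidence accounts for this result. From the compounds shown here alone, what remains open is whether the saturated chain carbon alone matters or the ring substituents also play a part. A plain unsubstituted benzyl group, or a phenyl ring carrying an amine, would help separate these two possibilities.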